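One more acetoxy on compound 3

A few compounds are considered here, and "the series" means these few. Any claim that something is new, unique, unknown or untested is made for them only; others in the source may bear on it.

In a functional assay on LNCaP cells (Homo sapiens) for cytotoxicity, read by sulforhodamine B assay, with a stated time of 72 h (on this read-out higher numbers stand for an effect only at larger amounts of compound and lower numbers for an effect already at smaller amounts), compound 3 `CCCC[C@H](OC(C)=O)[C@@H](OC(C)=O)[C@H](OC(C)=O)[C@H]1CC=CC(=O)O1` gives 3.2 ug/mL and compound 1 `CCCC[C@H](OC(C)=O)[C@@H](O)[C@H](O)[C@@H]1OC(=O)C=C[C@@H]1OC(C)=O` gives 4.5 ug/mL so these two sit within the usual scatter of each other. Compound 2 `CCCC[C@@H](/C=C\[C@@H]1OC(=O)C[C@@H](OC)[C@@H]1O)OC(C)=O` reads > 20 ug/mL as a limit of the assay and not a number. Compound 4 `CCCC[C@H](OC(C)=O)[C@@H](OC(C)=O)[C@H](OC(C)=O)[C@@H]1OC(=O)C=C[C@@H]1OC(C)=O` differs from compound 3 by one change, acetoxy in place of hydrogen on a saturated ring carbon. Among the compounds with values here, no measured pair shows this change alone, so compound 3 at 3.2 ug/mL remains the starting point. The expected 1.1-fold lower number from compound 3 to compound 4 (0.03 log units; within the scatter) in this assay is small and stays within the scatter, with no direction favoured. Compound 4 is estimated at 3 ug/mL with an expected range from 1 ug/mL to 9 ug/mL once measured.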

Compound 4, concentration for half-maximal effect: 1.9 ug/mL
The estimate for compound 4 lay 1.6-fold (0.20 log units) above the measured number; measured number inside the range.
By their numbers in this assay, from the lowest: compounds 4, 3 and 1 (each within the scatter of the next, the first and the last beyond it). At a limit, above all of these: compound 2.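

This is the first step shown that changes one place alone, and in this assay it reads a 1.7-fold lower number from compound 3 to compound 4 (0.23 log units; within the scatter). The saturated ring carbon two ring bonds from the ring oxygen can therefore carry an acetoxy in place of hydrogen with no change beyond the scatter. The step is too small to rank the two compounds.

Going by these compounds, whether an amine or a longer ester such as butyryloxy on this same carbon would read alike stays open. The cause of the step also stays open, as nothing at hand bears on it.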